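The source may hold more compounds than are shown below. What is called first, only, known or untested is meant among the compounds shown, and "the series" means these compounds.

Series notes. Compound 1 `COc1ccc(-n2nncc2CN2C(=O)C3(C(C#N)=C(N)Oc4c3c3nc5ccccc5nc3c3ccccc43)c3ccccc32)cc1` carries a 4-methoxyphenyl group; compound 2 `CC(=O)Nc1ccc(-n2nncc2CN2C(=O)C3(C(C#N)=C(N)Oc4c3c3nc5ccccc5nc3c3ccccc43)c3ccccc32)cc1` carries a 4-acetamidophenyl group on the same core. Compound 3 `CC(=O)Nc1ccc(-n2nncc2CN2C(=O)C3(C(C#N)=C(N)Oc4c(N)cc5nc6ccccc6nc5c43)c3ccccc32)cc1` keeps the 4-acetamidophenyl group on a second core, and compound 4 `COc1ccc(-n2nncc2CN2C(=O)C3(C(C#N)=C(N)Oc4c(N)cc5nc6ccccc6nc5c43)c3ccccc32)cc1`, not yet measured, joins that second core with the 4-methoxyphenyl group of compound 1. The difference between the core of compound 2 and the core of compound 3 is not broken down here.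

In a functional assay on HCT-116 cells (Homo sapiens) for antiproliferative activity, read by MTT assay, with a stated time of 48 h (on this read-out lower numbers stand for stronger inhibition and higher numbers for weaker inhibition), compound 1 reaches only a limit of the assay, > 50000 nM. In this assay compound 2 likewise reaches only a limit, > 50000 nM. Compound 3 also reaches only a limit, > 50000 nM. The change from compound 2 to compound 1, (methoxy in place of acetamido on an aromatic carbon), therefore gives a step whose size cannot be read: a step that the two limits leave unreadable from compound 2 to compound 1. All three values sit at the same limit (the limit of > 50000 nM in this assay, at which 3 of the 3 values shown sit), so no order among compounds 1, 2 and 3 can be stated.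

The change from compound 3 to compound 4 is the same change, (methoxy in place of acetamido on an aromatic carbon), at the same described place. Going by the values given here, the measured pair offers no readable size for this change, and no other pair in the set carries it. Among the compounds with values here, the only guide is that compounds 1, 2 and 3 all stand at the limit. Compound 4 is therefore expected to stay at or near that limit, the expected step being a step that the limit leaves unreadable from compound 3 to compound 4. The estimate for compound 4 in this assay is 60000 nM, with a range from 5000 nM to 200000 nM.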

Compound 4, half-maximal inhibitory concentration: > 50000 nM
Compound 4 ended at the assay's limit; the forecaster's own chance of this, stated with the estimate: 85%; the middle value lies beyond the limit too.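

The change from compound 3 to compound 4 gives no readable step in this assay, because both values are limits of the assay and not numbers: the limit of > 50000 nM in this assay, at which 4 of the 4 values shown sit.

The compounds shown leave open how far any of the four lies beyond that limit, and so whether the 4-acetamidophenyl to 4-methoxyphenyl change or the difference between the two cores has any effect on this read-out.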